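Replacing the pyrazole on the carboxylic acid core

The compounds below may be only part of what the source reports. "The series", "measured", "known", "first", "only" and "open" are said of these compounds alone.

Compound 1 `Cc1cc(C)cc(-c2c(C)nn(-c3nc(-c4ccc(Cl)c(Cl)c4)c(SC(C)C)s3)c2C(=O)O)c1` was tested in a functional assay on BJAB cells (Homo sapiens) for antiproliferative activity, with a stated time of 4 days (a higher number here means that more compound is needed for the effect, a lower number that less compound is needed), and gave 2700 nM. Compound 2 `Cc1nn(-c2nc(-c3ccc(Cl)c(Cl)c3)c(SC(C)C)s2)c(C(=O)O)c1-c1cnn(C)c1` is its close relative, with 1-methyl-1H-pyrazol-4-yl in place of 3,5-dimethylphenyl on an aromatic carbon of the shared core, and in this assay compound 2 gives 6800 nM. For the measured compounds named here, the single measured step, a 2.5-fold higher number from compound 1 to compound 2 (0.40 log units; beyond the scatter), shows that this swap worsened the read-out beyond the scatter, so compound 2 stands with the highest of the two numbers so far, and its nearest neighbour is compound 1.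

Compound 3 `COc1cncc(-c2c(C)nn(-c3nc(-c4ccc(Cl)c(Cl)c4)c(SC(C)C)s3)c2C(=O)O)c1` carries the change (5-methoxypyridin-3-yl in place of 1-methyl-1H-pyrazol-4-yl on an aromatic carbon). Going by the values given here, no measured pair shows this exact exchange; the only step that bears on it is the one from compound 1 to compound 2, which moved the number upward when a six-membered carbocycle gave way to the five-membered pyrazole. Because that step, a 2.5-fold higher number from compound 1 to compound 2 (0.40 log units; beyond the scatter), was modest, a return to a six-membered aromatic ring is expected to bring the number somewhat back down, as a step of a 1.7-fold lower number from compound 2 to compound 3 (0.23 log units; within the scatter). Compound 3 is therefore estimated at 4000 nM, with a range from 1500 nM to 10000 nM.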

Compound 3, half-maximal effective concentration: 21000 nM
For compound 3 the middle estimate is 5.3-fold (0.72 log units) below the measured one; measured number above the stated range.
By their numbers in this assay, from the lowest: compound 1; then compound 2; then compound 3.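

At this position on the shared core, a six-membered aromatic ring does not by itself lower the number: in this assay, putting 5-methoxypyridin-3-yl in place of 1-methyl-1H-pyrazol-4-yl gives a 3.1-fold higher number from compound 2 to compound 3 (0.49 log units; beyond the scatter), even though the two groups match in hydrogen-bond donors, hydrogen-bond acceptors and net charge. Ring size therefore does not order the series, since the other six-membered substituent, 3,5-dimethylphenyl, gives the lowest number of the three, and 5-methoxypyridin-3-yl in its place gives a 7.8-fold higher number from compound 1 to compound 3 (0.89 log units; beyond the scatter), with the five-membered ring of compound 2 falling between them. Nothing available here accounts for this order.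

The compounds shown leave open whether the rise belongs to the ring nitrogen or to the methoxy group of compound 3, as they include neither a plain pyridin-3-yl nor a 3-methoxyphenyl group at this place. They also leave open whether the same order of these three substituents would hold if the carboxylic acid on the core gave way to a primary amide.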